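Fluorophenyl esters on the shared core: acetate to benzoates

The source may report more compounds than this note shows. Statements on the series, on what has been measured and on what is new or still open speak of the compounds shown alone.

Compound 1 `C=C1C(=O)[C@@]23C(=O)OC[C@]4(C(=O)CCC(C)(C)[C@H]4C=O)[C@@H]2CC[C@@H]1[C@H]3OC(C)=O` is the acetate of the shared core. In a functional assay on CaEs17 cells (Homo sapiens) for cytotoxicity, read by MTT assay, with a stated time of 72 h (a lower number here means a stronger inhibitor, a higher number a weaker inhibitor), compound 1 gives 1350 nM, the lowest of the two numbers in hand. Compound 2 `C=C1C(=O)[C@@]23C(=O)OC[C@]4(C(=O)CCC(C)(C)[C@H]4C=O)[C@@H]2CC[C@@H]1[C@H]3OC(=O)c1ccc(F)cc1` carries a 4-fluorophenyl in place of methyl on the carbonyl carbon. In this assay compound 2 gives 8310 nM. The resulting step is a 6.2-fold higher number from compound 1 to compound 2 (0.79 log units; beyond the scatter).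

Compound 3 `C=C1C(=O)[C@@]23C(=O)OC[C@]4(C(=O)CCC(C)(C)[C@H]4C=O)[C@@H]2CC[C@@H]1[C@H]3OC(=O)c1ccccc1F` has not been measured. Its change from compound 1 is 2-fluorophenyl in place of methyl on a carbonyl carbon. For the measured compounds named here, the one measured step that bears on it is the same exchange at the same place with 4-fluorophenyl entering, a 6.2-fold higher number from compound 1 to compound 2 (0.79 log units; beyond the scatter), a weakening beyond the scatter. Going by the values given here, no measured pair separates a 2-fluorophenyl from a 4-fluorophenyl, so the size is taken from compound 2 with widened bounds, and a higher number than compound 1 is expected in this assay. For compound 3 the expected step is a 4.4-fold higher number from compound 1 to compound 3 (0.65 log units; beyond the scatter). Compound 3 is estimated at 6000 nM, within 2200 nM to 16000 nM.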

Compound 3, half-maximal inhibitory concentration: 8550 nM
Compound 3: the middle estimate sits 1.4-fold (0.15 log units) below what was measured, within the range that was stated.
By their numbers in this assay, from the lowest: compound 1; then compounds 2 and 3 (each within the scatter of the next).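

In this assay, 2-fluorophenyl in place of methyl on the carbonyl carbon gives a 6.3-fold higher number from compound 1 to compound 3 (0.80 log units; beyond the scatter) and so also weakens the acetate, which shows that the loss is not confined to the 4-fluorophenyl group. The exchange of 4-fluorophenyl for 2-fluorophenyl gives a 1.0-fold higher number from compound 2 to compound 3 (0.01 log units; within the scatter) and leaves the two fluorophenyl esters indistinguishable in this read-out. Nothing at hand accounts for the gap between these esters and the acetate.

From the compounds shown here alone, whether the fluorine contributes at all remains open, and a plain phenyl ester would address that. A longer chain such as butanoyl, or an ester carrying an amine, would show whether the loss requires an aromatic ring or also appears with other groups at this carbonyl carbon.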